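The source may report more compounds than this note shows. Statements on the series, on what has been measured and on what is new or still open speak of the compounds shown alone.

Measured compounds:
Compound 1, `O=C(Nc1cc(Sc2ncn[nH]2)c(O)c2ccccc12)c1ccc([N+](=O)[O-])cc1`. In a functional assay on HCT-116 cells (Homo sapiens) for antiproliferative activity, read by MTT assay, with a stated time of 48 h (a lower number here means a stronger inhibitor, a higher number a weaker inhibitor), compound 1 gives > 100000 nM, which is a limit of the assay and not a number.
Compound 2, `Cc1nnc(Sc2cc(NC(=O)c3ccc(Cl)cc3)c3ccccc3c2O)s1`. In this assay compound 2 gives > 100000 nM, again a limit.
Compound 3, `O=C(Nc1cc(Sc2ncnc3nc[nH]c23)c(O)c2ccccc12)c1ccc(Cl)cc1`. In this assay compound 3 gives > 100000 nM, also a limit.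

Compound 3 therefore stands only at a limit, as do the other two measured compounds, all of them at the limit of > 100000 nM in this assay, at which 3 of the 3 values shown sit. For the measured compounds named here, the one step that can be laid out between measured compounds, a step that the two limits leave unreadable from compound 2 to compound 3, is unreadable for the same reason, since both ends are limits.

Compound 4, `O=C(Nc1cc(Sc2nncs2)c(O)c2ccccc12)c1ccc(Cl)cc1`, is not yet measured. Its change from compound 3 is a group of 5 heavy atoms (2 carbon, 2 nitrogen, 1 sulfur; one five-membered aromatic ring with 3 hetero atoms) in place of a group of 9 heavy atoms (5 carbon, 4 nitrogen; one five-membered aromatic ring with 2 hetero atoms, one six-membered aromatic ring with 2 hetero atoms), on a sulfur. Compound 2 already carries a five-membered aromatic ring with 3 hetero atoms on the same sulfur and sits at the limit. Going by the values given here, the only measured evidence bearing on the step to compound 4 is thus the unreadable step that the two limits leave unreadable from compound 2 to compound 3 and the shared limit (the limit of > 100000 nM in this assay, at which 3 of the 3 values shown sit), so no direction can be read and no size beyond the scatter can be claimed.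

The expected step from compound 3 to compound 4 is a number no higher from compound 3 to compound 4 (the limit leaves the size open), which is to say no movement away from the limit. Compound 4 is expected to give 100000 nM in this assay, with a range from 30000 nM to 300000 nM, most probably reported once more only as a limit.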

Compound 4, half-maximal inhibitory concentration: > 100000 nM
Compound 4: only a limit was reported; the forecaster's own chance of this, stated with the estimate: 80%; the middle value lies on the limit itself.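

In this assay compound 4 gives > 100000 nM, which is a limit and not a number. The new steps to compound 4 from compound 2 and from compound 3 therefore cannot be read. The compounds shown leave open whether any change to the series would give a measurable value, as all remain at the limit: the limit of > 100000 nM in this assay, at which 4 of the 4 values shown sit.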